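Sulfonamide cap variation on the shared core

The compounds below may be only part of what the source reports. "The series", "measured", "known", "first", "only" and "open" are said of these compounds alone.

In an assay on isolated protein for inhibition of Apoptosis regulator Bcl-2/Bcl-2 homologous antagonist/killer (Homo sapiens), read by surface plasmon resonance, with a stated time of 1 h (on this read-out higher numbers stand for an effect only at larger amounts of compound and lower numbers for an effect already at smaller amounts), compound 1 `CCS(=O)(=O)NC(=O)c1ccc(N2CCN(Cc3ccccc3-c3ccc(Cl)cc3)CC2)cc1` gives 5310 nM. Among the compounds with values here, compound 2 `CC1(C)C2CC[C@@]1(CS(=O)(=O)NC(=O)c1ccc(N3CCN(Cc4ccccc4-c4ccc(Cl)cc4)CC3)cc1)C(=O)C2` gives 1470 nM in this assay, and it holds the lowest of the two numbers measured so far; its nearest neighbour is compound 1, with the step of a 3.6-fold lower number from compound 1 to compound 2 (0.56 log units; beyond the scatter).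

Compound 3 `CC1(C)[C@@]2(C)CC[C@H](CS(=O)(=O)NC(=O)c3ccc(N4CCN(Cc5ccccc5-c5ccc(Cl)cc5)CC4)cc3)[C@]1(C)C2` carries a group of 11 heavy atoms (11 carbon; one four-membered non-aromatic ring of carbon only, one six-membered non-aromatic ring of carbon only) in place of a group of 10 heavy atoms (9 carbon, 1 oxygen; 2 five-membered non-aromatic rings of carbon only), on a saturated chain carbon bound to a sulfonyl sulfur. Within the data shown here, the only measured step at this position is a 3.6-fold lower number from compound 1 to compound 2 (0.56 log units; beyond the scatter), in which a small group on the saturated chain carbon bound to a sulfonyl sulfur was exchanged for a larger bicyclic one and the number fell. No measured pair compares two different bicyclic groups at this position, so the effect of swapping one for another is not shown by the data. Compound 3 retains a group of comparable size to that of compound 2, and the expectation is therefore a number close to that of compound 2, with the step of a 1.1-fold higher number from compound 2 to compound 3 (0.04 log units; within the scatter) expected to lie within or only slightly beyond the scatter. For compound 3 in this assay the estimate is 1600 nM, with a range from 500 nM to 5000 nM.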

Compound 3, half-maximal effective concentration: 560 nM
Compound 3: middle estimate off by 2.9-fold (0.46 log units), on the high side, and the stated range covers the measured number.
By their numbers in this assay, from the lowest: compound 3; then compound 2; then compound 1.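

Working notes on the cap position: in this assay two different large groups at this position can now be compared directly, and a 2.6-fold lower number from compound 2 to compound 3 (0.42 log units; beyond the scatter) shows that the number depends on which group sits on the saturated chain carbon bound to a sulfonyl sulfur, not only on a large group being present. The entering group has 11 carbon and 0 hydrogen-bond acceptors, while the group it replaces has 9 carbon, 1 oxygen and 1 hydrogen-bond acceptor, so the oxygen of compound 2 is not required for a lower number at this position. Measured against the small group of compound 1, the whole change is a 9.5-fold lower number from compound 1 to compound 3 (0.98 log units; beyond the scatter) and is the largest step among the three compounds, but no available measurement bears on what lies behind it.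

The ring types, the oxygen and the defined stereocentres all change together in the step to compound 3, so their separate contributions remain unresolved. Also open, on these data alone, is how a carboxylic acid, an amine or a longer chain on this same saturated chain carbon would compare on the shared core.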